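Amine-to-benzyl swap on the core of compound 2

A few compounds are considered here, and "the series" means these few. Any claim that something is new, unique, unknown or untested is made for them only; others in the source may bear on it.

Measured so far:
compound 1 `O=C(NCc1ccc(F)cc1)c1nc(NCCO)c2cccnc2c1O` — in a functional assay on HCT-116 cells (Homo sapiens) for cytotoxicity, read by MTT assay, with a stated time of 72 h (a higher number here means a weaker inhibitor, a lower number a stronger inhibitor), compound 1 gives "not determined" (no result reported)
compound 2 `CN(C)CCCNc1c(C(=O)NCc2ccc(F)cc2)nc(Br)c2cccnc12` — in this assay compound 2 gives > 10000 nM

Compound 1 contributes no number to this assay. For compound 2 the result in this assay is only a limit, > 10000 nM, not a measured number. Compound 2 thus stands at the limit of > 10000 nM in this assay, at which 1 of the 2 values shown sits, and nothing else in the set gives it a position relative to another compound.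

Compound 3 `O=C(NCc1ccc(F)cc1)c1nc(Br)c2cccnc2c1NCc1ccccc1` differs from compound 2 in one place: phenyl in place of 2-(dimethylamino)ethyl on a saturated chain carbon bound to a nitrogen on an aromatic ring. Going by the values given here, no step between measured compounds exists in this assay, so this change is untested here. With compound 2 at a limit, the step from compound 2 to compound 3 is expected to be a step that the limit leaves unreadable from compound 2 to compound 3, that is, no change beyond the scatter in either direction. Compound 3 is estimated at 12000 nM, with a range from 3000 nM to 50000 nM, and a second limit rather than a number is as likely as not.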

Compound 3, half-maximal inhibitory concentration: > 20000 nM
Compound 3: a limit, no number; the forecaster's own chance of this, stated with the estimate: 55%; at least 1.6-fold (0.22 log units) between middle value and limit.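

Going by these compounds alone, compound 2 and compound 3 both return only limits in this assay, not numbers, so no step between them can be read. Still open, from the compounds shown here alone, is whether phenyl in place of 2-(dimethylamino)ethyl changes cytotoxicity at all, and at what concentration either compound reaches half-maximal inhibition.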